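Ring replacement at the acid-bearing bicycle in the series

The source may report more compounds than this note shows. Statements on the series, on what has been measured and on what is new or still open speak of the compounds shown alone.

Measured compounds:
compound 1 `CC(C)c1onc(-c2c(Cl)cccc2Cl)c1COc1ccc(-c2ccc3sc(C(=O)O)cc3c2)cc1`: 530 nM
compound 2 `CC(C)c1onc(-c2c(Cl)cccc2Cl)c1COc1ccc(-c2ccc3sc(C(=O)O)cc3n2)cc1`: 1700 nM

In a functional assay on CV-1 cells for agonist activity at Bile acid receptor (Homo sapiens), read by a luciferase reporter (a lower number here means that less compound is needed, a higher number that more compound is needed for the effect), compound 2 gives the higher of the two numbers, and compound 1 the lower. For the measured compounds named here, the single measured step, a 3.2-fold higher number from compound 1 to compound 2 (0.51 log units; beyond the scatter), shows the cost of placing a ring nitrogen in the six-membered aromatic ring of the acid-bearing bicycle.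

Compound 3 `CC(C)c1onc(-c2c(Cl)cccc2Cl)c1COc1ccc(-c2ccc3c(c2)CC(C(=O)O)C3)cc1` is not yet measured. It differs from compound 2 by a group of 12 heavy atoms (10 carbon, 2 oxygen; one five-membered non-aromatic ring of carbon only, one six-membered aromatic ring of carbon only) in place of a group of 12 heavy atoms (8 carbon, 1 nitrogen, 2 oxygen, 1 sulfur; one five-membered aromatic ring with 1 hetero atom, one six-membered aromatic ring with 1 hetero atom), on an aromatic carbon. Going by the values given here, the step from compound 1 to compound 2 bears only partly on this change: the ring nitrogen leaves again, which points toward the number of compound 1, but the acid now sits on a five-membered non-aromatic ring, for which no measured step exists. An expected step of a 2.4-fold lower number from compound 2 to compound 3 (0.39 log units; beyond the scatter) is therefore set downward, with a wide range. Compound 3 is expected to give 700 nM, between 150 nM and 3500 nM in this assay.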

Compound 3, half-maximal effective concentration: 490 nM
Estimate against measurement, compound 3: 1.4-fold (0.15 log units) above; the measured number falls inside the stated range.
By their numbers in this assay, from the lowest: compounds 3 and 1 (each within the scatter of the next); then compound 2.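

In this assay the change to 2-carboxy-2,3-dihydro-1H-inden-5-yl gives a 3.5-fold lower number from compound 2 to compound 3 (0.54 log units; beyond the scatter), while the comparison with 2-carboxy-1-benzothiophen-5-yl gives a 1.1-fold lower number from compound 1 to compound 3 (0.03 log units; within the scatter). The position therefore accepts the acid on a five-membered non-aromatic ring of carbon only, and neither the sulfur nor the aromatic five-membered ring is required to match compound 1 in this series. Nothing available explains why these two different rings give matching numbers.

On these data alone, whether a ring nitrogen in the six-membered ring of compound 3 would carry the same cost as in the step to compound 2 remains open. Also open, as far as these compounds go, is whether a tetrazole or a primary amide could stand in place of the carboxylic acid on the new ring.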